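This account rests on a few compounds, and the source may have more. Where it says the series, first, only, none or still open, it means among the compounds named here.

Of the compounds shown here, three built on one shared core have been tested in a functional assay on KB cells (Homo sapiens) for antiproliferative activity, read by sulforhodamine B assay, with a stated time of 3 days; a higher number here means that more compound is needed for the effect, a lower number that less compound is needed. Compound 1 `CCC1=C(O)c2c(oc(-c3ccc(Br)cc3)cc2=O)C(CC)(CC)C1=O` carries a 4-bromophenyl group on that core. In this assay compound 1 gives only a limit, > 48.1 uM, so its true value is not known. Compound 2 `CCC1=C(O)c2c(oc(-c3ccccc3C(F)(F)F)cc2=O)C(CC)(CC)C1=O` gives 45.6 uM in this assay. Compound 3 `CCC1=C(O)c2c(oc(-c3ccc(OC)c(OC)c3OC)cc2=O)C(CC)(CC)C1=O` gives 9.4 uM in this assay. Compound 1 therefore stands at the edge of what the measurement can report, where (the limit of > 48.1 uM in this assay, at which 1 of the 3 values shown sits).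

Compound 4 `CCC1=C(O)c2c(oc(-c3ccc(O)c(C)c3C)cc2=O)C(CC)(CC)C1=O` differs from compound 1 in one place: 4-hydroxy-2,3-dimethylphenyl in place of 4-bromophenyl on an aromatic carbon. Among the compounds with values here, no measured pair of compounds shows exactly this change, so no measured step tells how large its effect should be. The expected step is an at least 2.4-fold lower number from compound 1 to compound 4 (0.38 log units; beyond the scatter), in the direction of less compound being needed, on the ground that compound 3 gives 9.4 uM while the other two sit near the top of the range. Compound 4 is estimated at 20 uM, with a likely range from 6 uM to 60 uM.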

Compound 4, concentration for half-maximal effect: 6.5 uM
Estimate against measurement, compound 4: 3.1-fold (0.49 log units) above, within the range that was stated.
By their numbers in this assay, from the lowest: compounds 4 and 3 (each within the scatter of the next); then compound 2. At a limit, above all of these: compound 1.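

Replacing 4-bromophenyl with 4-hydroxy-2,3-dimethylphenyl on this aromatic carbon next to the ring oxygen gives an at least 7.4-fold lower number from compound 1 to compound 4 (0.86 log units; beyond the scatter) in this assay. This single change therefore moves the read-out by more than the usual scatter, showing that the choice of group at this position matters and that a phenyl ring carrying a hydroxy group and two methyl groups can sit here with less compound needed. From the compounds shown here alone, the true size of the step remains unknown and this figure is only a minimum, since compound 1 stands at a limit: the limit of > 48.1 uM in this assay, at which 1 of the 4 values shown sits.

The compounds shown do not separate the parts of this change: the hydroxy group, the two methyl groups and the loss of bromine. Also open, going by these compounds, is how an amine or a carboxylic acid on this phenyl ring would read in this assay.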